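Carboxy in place of (carboxymethyl)amino on the shared core

A few compounds are considered here, and "the series" means these few. Any claim that something is new, unique, unknown or untested is made for them only; others in the source may bear on it.

Measured values in an assay for inhibition of Indoleamine 2,3-dioxygenase 1 (Homo sapiens), with stated times of 10 min and 60 min; a lower number here means a stronger inhibitor, a higher number a weaker inhibitor:
- compound 1, `FC(F)(F)c1cc(NC[C@H]2CCCN2)c2cn[nH]c2c1`: 9580 nM
- compound 2, `O=[N+]([O-])c1cccc(CNc2cc(C(F)(F)F)cc3[nH]ncc23)c1`: the reported figure is a limit of the assay, > 100000 nM
- compound 3, `O=C(O)CNc1cccc(CNc2cc(C(F)(F)F)cc3[nH]ncc23)c1`: the reported figure is a limit of the assay, > 100000 nM

Going by the values given here, compound 3 stands at the limit of this assay, with no number of its own; compound 1 is the only member of the series with a measured number. Among the compounds with values here, the single step between measured neighbours, a step that the two limits leave unreadable from compound 2 to compound 3, runs between two limits and its size cannot be read. The shared evidence is the limit of > 100000 nM in this assay, at which 2 of the 3 values shown sit.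

Compound 4, `O=C(O)c1cccc(CNc2cc(C(F)(F)F)cc3[nH]ncc23)c1`, differs from compound 3 by carboxy in place of (carboxymethyl)amino on an aromatic carbon. Within the data shown here, no measured step bears on this change directly, and the one step that is known gives no size, so no direction can be drawn from it. Given that compound 3 sits at the limit > 100000 nM, compound 4 is expected to return a weak result as well, with a number no higher from compound 3 to compound 4 (the limit leaves the size open) as the expected step. The estimate for compound 4 in this assay is 100000 nM, within 20000 nM to 400000 nM.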

Compound 4, half-maximal inhibitory concentration: > 100000 nM
Compound 4 ended at the assay's limit; the forecaster's own chance of this, stated with the estimate: 70%; the middle value sits exactly at the limit.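

No step among compound 2, compound 3 and compound 4 can be read, since each stands at a limit and not at a number: the limit of > 100000 nM in this assay, at which 3 of the 4 values shown sit.

The compounds shown leave open whether any group at this place on the aromatic ring would give a measured number.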